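Swapping the Ring on a Sulfonamide Nitrogen

The source may hold more compounds than are shown below. What is called first, only, known or untested is meant among the compounds shown, and "the series" means these compounds.

Within the data shown here, compound 2 `N#Cc1c(-c2ccccc2)cn(-c2ccc(S(=O)(=O)Nc3nccs3)cc2)c1NC(=O)CCC(=O)O` holds the lower of the two values measured so far in a functional assay on HepG2 cells (Homo sapiens) for antiproliferative activity, read by sulforhodamine B assay, with a stated time of 48 h, tested at 25 uM; on this read-out higher numbers stand for a stronger effect at the one concentration tested and lower numbers for a weaker effect: compound 2 gives 36%. Compound 1 `CC(=O)Nc1c(C#N)c(-c2ccccc2)cn1-c1ccc(S(=O)(=O)Nc2ccccn2)cc1` differs from compound 2 in several places. In this assay compound 1 gives 62.7%, and that gap lies beyond the scatter. Compound 3 `N#Cc1c(-c2ccccc2)cn(-c2ccc(S(=O)(=O)Nc3ccccn3)cc2)c1NC(=O)CCC(=O)O` is the untested member of the set. It differs from compound 2 in one place only: pyridin-2-yl in place of 1,3-thiazol-2-yl on a sulfonamide nitrogen. Some rise is expected from this change because compound 1 gives 62.7% while also carrying pyridin-2-yl on the sulfonamide nitrogen, yet compound 1 and compound 2 differ elsewhere too, so how much of that gap belongs to the ring alone is unknown. The step of a number 10 percentage points higher from compound 2 to compound 3 (within the scatter) is expected to be a modest rise, near the edge of the scatter. Compound 3 is expected to reach 46%, within a range from 28% to 64%.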

Compound 3, a percentage reported as activity, at one concentration (the size of the read-out at that concentration, not a potency): 72%
For compound 3 the middle estimate is 26 percentage points below the measured one; measured number above the stated range.
By their numbers in this assay, from the lowest: compound 2; then compounds 1 and 3 (each within the scatter of the next).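

With all else held the same, the ring on the sulfonamide nitrogen has a large effect in this assay: pyridin-2-yl in place of 1,3-thiazol-2-yl gives a number 36 percentage points higher from compound 2 to compound 3 (beyond the scatter) in this series. The chain on the amide shows no such effect once pyridin-2-yl is present, since carboxymethyl in place of hydrogen on a saturated chain carbon bound to a carbonyl carbon gives a number 9.3 percentage points higher from compound 1 to compound 3 (within the scatter) and so cannot be told apart from no change. The data offer no measured explanation for why one ring serves so much better than the other.

The compounds shown leave open whether a phenyl or pyrimidin-2-yl ring on the sulfonamide nitrogen would match pyridin-2-yl. They also leave open whether the ring step keeps its size when the acetyl group of compound 1 replaces the chain ending in a carboxylic acid.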